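Dicarboxyethyl Amide Variant of Compound 2

The source may report more compounds than this note shows. Statements on the series, on what has been measured and on what is new or still open speak of the compounds shown alone.

Three measured compounds share one core and differ only in the group carried on the amide-type nitrogen. Compound 1 `CCn1c(C(=O)NCC(=O)OC)ccc1C(CC)(CC)c1ccc(OCS(=O)(=O)c2ccccc2)c(C)c1` gives 20000 nM in a functional assay on BXPC-3 cells (Homo sapiens) for antiproliferative activity, read by MTT assay, with a stated time of 24 h; on this read-out higher numbers stand for weaker inhibition and lower numbers for stronger inhibition. Compound 2 `CCn1c(C(=O)N[C@@H](C)CO)ccc1C(CC)(CC)c1ccc(OCS(=O)(=O)c2ccccc2)c(C)c1` gives 15300 nM in this assay, and compound 3 `CCn1c(C(=O)NC2(CO)CC2)ccc1C(CC)(CC)c1ccc(OCS(=O)(=O)c2ccccc2)c(C)c1` gives 45400 nM. Compound 2 holds the lowest of the three numbers, yet its gap to compound 1 is within the scatter a 1.3-fold lower number from compound 1 to compound 2 (0.12 log units; within the scatter), so no order between those two can be claimed; only compound 3 lies beyond it a 3.0-fold higher number from compound 2 to compound 3 (0.47 log units; beyond the scatter).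

Compound 4 `CCn1c(C(=O)N[C@@H](CC(=O)O)C(=O)O)ccc1C(CC)(CC)c1ccc(OCS(=O)(=O)c2ccccc2)c(C)c1` is not yet measured. Against compound 2 the change is 1,2-dicarboxyethyl in place of 1-(hydroxymethyl)ethyl on an amide-type nitrogen. Among the compounds with values here, the steps that bear on this position are the moves onto the 1-(hydroxymethyl)cyclopropyl group, a 2.3-fold higher number from compound 1 to compound 3 (0.36 log units; beyond the scatter) and a 3.0-fold higher number from compound 2 to compound 3 (0.47 log units; beyond the scatter), both modest rises, whereas the exchange between the (methoxycarbonyl)methyl and 1-(hydroxymethyl)ethyl groups stayed within the scatter. The 1,2-dicarboxyethyl group is a larger departure than either, so a modest rise in the number, rather than a fall, is expected. Compound 4 is therefore estimated to give about 28000 nM in this assay, with a range from 11000 nM to 70000 nM. The expected step of a 1.8-fold higher number from compound 2 to compound 4 (0.26 log units; within the scatter) is thus judged modest and toward weaker inhibition.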

Compound 4, half-maximal inhibitory concentration: > 50000 nM
Compound 4 gave a limit, no number; the forecaster's own chance of this, stated with the estimate: 15%; at least 1.7-fold (0.25 log units) between middle value and limit.
By their numbers in this assay, from the lowest: compounds 2 and 1 (each within the scatter of the next); then compound 3. At a limit, above all of these: compound 4.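

In this assay compound 4 reaches a limit of the assay, not a number: the limit of > 50000 nM in this assay, at which 1 of the 4 values shown sits.

At this amide-type nitrogen, the exchange of (methoxycarbonyl)methyl for 1-(hydroxymethyl)ethyl had stayed within the scatter, but the 1,2-dicarboxyethyl group moves the read-out toward weaker inhibition beyond the scatter against both: an at least 3.2-fold higher number from compound 2 to compound 4 (0.51 log units; beyond the scatter) and an at least 2.5-fold higher number from compound 1 to compound 4 (0.39 log units; beyond the scatter). Against the 1-(hydroxymethyl)cyclopropyl group the result is less decisive, an at least 1.1-fold higher number from compound 3 to compound 4 (0.04 log units; that floor lies within the scatter), so this step sets only a floor and does not separate the two groups.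

From the compounds shown here alone, the true size of all three steps stays unknown, as the limit gives only their lower bounds. Also open is whether the rise follows the 1,2-dicarboxyethyl group as a whole or one part of it, since the compounds shown include neither a carboxymethyl group with a single carboxylic acid, nor the methyl esters of the 1,2-dicarboxyethyl group, nor an amine on this chain.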